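A few compounds are considered here, and "the series" means these few. Any claim that something is new, unique, unknown or untested is made for them only; others in the source may bear on it.

Measured so far:
compound 1, `CCCn1ncc2c(=N)n(C)c(=O)[nH]c21`: 5% in an assay on membranes from brain for binding affinity to adenosine receptor A1 (Rattus norvegicus), read by radioligand binding, tested at 20 uM; a higher number here means more inhibition at the concentration tested (going by the name of the read-out), a lower number less inhibition
compound 2, `Cn1c(=O)[nH]c2c(cnn2-c2cc(Cl)cc(Cl)c2)c1=N`: 29% in this assay

Of these two, compound 1 stands lowest in this assay; its nearest neighbour is compound 2, whose value lies higher by a margin beyond the scatter. Compound 3 `Cn1c(=O)[nH]c2c(cnn2C)c1=N` differs from compound 1 by hydrogen in place of ethyl on a saturated chain carbon bound to an aromatic nitrogen. Going by the values given here, no step between measured compounds is available to size this change. The step is expected to be small, no change at the digits printed from compound 1 to compound 3 (within the scatter), in no direction beyond the scatter, because compound 1 gives 5% and leaves little room below. Compound 3 is therefore expected to give 5%, within -8% to 20%.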

Compound 3, a percentage reported as inhibition, at one concentration (the size of the read-out at that concentration, not a potency): 6%
The estimate for compound 3 lay 1 percentage points below the measured number; the measured number falls inside the stated range.
By their numbers in this assay, from the lowest: compounds 1 and 3 (each within the scatter of the next); then compound 2.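

Hydrogen in place of ethyl on a saturated chain carbon bound to an aromatic nitrogen gives a number 1 percentage points higher from compound 1 to compound 3 (within the scatter) in this assay. At this position, then, propyl and methyl cannot be told apart in this read-out, although both compounds lie so near the bottom of the scale that the comparison has little room to show a loss. Nothing at hand accounts for this result. The compounds shown leave open whether a benzyl group or an unsubstituted phenyl on that nitrogen would raise the number, and whether a butyl chain would differ from propyl.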